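The source may report more compounds than this note shows. Statements on the series, on what has been measured and on what is new or still open speak of the compounds shown alone.

Compound 2, `CCc1nc2ccc(-n3ccc(OCc4ccc(F)cc4)cc3=O)cc2n1C`, was measured in an assay on CHO cells for displacement of a labelled ligand from melanin-concentrating hormone receptor 1 (Rattus norvegicus), read by scintillation counting, with a stated time of 1 h (a higher number here means a weaker inhibitor, a lower number a stronger inhibitor), where compound 2 gives 38 nM. Two close relatives share its core and differ only in the group on the aromatic carbon. Compound 1, `Cc1nc2ccc(-n3ccc(OCc4ccc(F)cc4)cc3=O)cc2n1C`, carries a methyl there and in this assay compound 1 gives 65 nM. Compound 3, `Cn1c(C2CC2)nc2ccc(-n3ccc(OCc4ccc(F)cc4)cc3=O)cc21`, carries a cyclopropyl and in this assay compound 3 gives 28 nM. On these three numbers compound 2 is separated from each neighbour by less than the usual scatter: there is a 1.7-fold lower number from compound 1 to compound 2 (0.23 log units; within the scatter) and a 1.4-fold lower number from compound 2 to compound 3 (0.13 log units; within the scatter). Going by the values given here, only the step of a 2.3-fold lower number from compound 1 to compound 3 (0.37 log units; beyond the scatter) is large enough to count as a real, if modest, change.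

Compound 4, `Cn1c(CC(C)(C)C)nc2ccc(-n3ccc(OCc4ccc(F)cc4)cc3=O)cc21`, takes the next step outward from compound 2: tert-butyl in place of methyl on a saturated chain carbon bound to an aromatic carbon. Among the compounds with values here, two measured steps bear on it. Adding one carbon at that chain position, from compound 1 to compound 2, stayed within the scatter, and the bulkier ring in compound 3 brought only a modest gain over compound 1. Within the data shown here, neither points to a large step in this assay for compound 4, and the much larger tert-butyl has no measured precedent here. The number for compound 4 is therefore expected to sit close to compound 2, with a 1.2-fold lower number from compound 2 to compound 4 (0.07 log units; within the scatter) as the estimated step. Compound 4 is estimated at 32 nM, within a range from 10 nM to 110 nM.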

Compound 4, half-maximal inhibitory concentration: > 1000 nM
Compound 4: a limit, no number; the forecaster's own chance of this, stated with the estimate: 3%; middle value at least 31-fold (1.49 log units) from the limit.
By their numbers in this assay, from the lowest: compounds 3, 2 and 1 (each within the scatter of the next, the first and the last beyond it). At a limit, above all of these: compound 4.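

The reading for compound 4 is a limit of the assay and not a number: the limit of > 1000 nM in this assay, at which 1 of the 4 values shown sits. Even so, the group on the aromatic carbon clearly matters, since changing it to neopentyl gives an at least 26-fold higher number from compound 2 to compound 4 (1.42 log units; beyond the scatter), and the same change gives an at least 35-fold higher number from compound 3 to compound 4 (1.55 log units; beyond the scatter) and an at least 15-fold higher number from compound 1 to compound 4 (1.18 log units; beyond the scatter). Among compounds 1, 2 and 3, methyl, ethyl and cyclopropyl gave steps that were at most modest, so only compound 4 shows that this place does not accept every carbon group and that going from ethyl to neopentyl can cost a large loss of binding.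

As far as these compounds go, because compound 4 sits at a limit, the true size of these steps stays unknown, and they can only be read as minimum sizes. The compounds shown also leave open where between ethyl and neopentyl the loss sets in, which a propyl or isobutyl chain would address, and whether a neopentyl-length chain ending in an amine or a carboxylic acid would fare any differently at this place.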